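Substituent swap at the benzyl group of compound 3

The source may hold more compounds than are shown below. What is called first, only, known or untested is meant among the compounds shown, and "the series" means these compounds.

Measured so far:
compound 1, `O=c1ccoc2cc(OCc3cn(Cc4ccccc4)nn3)ccc12`, 42900 nM
compound 2, `Cc1cccc(Cn2cc(COc3ccc4c(=O)ccoc4c3)nn2)c1`, 11700 nM
compound 3, `O=c1ccoc2cc(OCc3cn(Cc4ccc(Cl)cc4Cl)nn3)ccc12`, > 100000 nM

Three analogues sharing one core were tested in a functional assay on SW480 cells (Homo sapiens) for cytotoxicity, read by MTT assay, with a stated time of 48 h; on this read-out higher numbers stand for weaker inhibition and lower numbers for stronger inhibition. Compound 1 carries a plain phenyl on the saturated chain carbon bound to an aromatic nitrogen and gives 42900 nM. Compound 2 carries a 3-methylphenyl there and gives 11700 nM. Compound 3 is the 2,4-dichlorophenyl analogue; its result is only a limit of the assay, > 100000 nM, so it sits at the weak end of the values shown (the limit of > 100000 nM in this assay, at which 1 of the 3 values shown sits).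

The step to compound 3 from compound 1 was an at least 2.3-fold higher number from compound 1 to compound 3 (0.36 log units; beyond the scatter), and from compound 2 an at least 8.5-fold higher number from compound 2 to compound 3 (0.93 log units; beyond the scatter). The change from compound 1 to compound 2, a 3.7-fold lower number from compound 1 to compound 2 (0.56 log units; beyond the scatter), shows a single substituent on that phenyl can move the number modestly.

Compound 4, `O=c1ccoc2cc(OCc3cn(Cc4cccc([N+](=O)[O-])c4)nn3)ccc12`, differs from compound 3 as follows: 3-nitrophenyl in place of 2,4-dichlorophenyl on a saturated chain carbon bound to an aromatic nitrogen. Since compound 3 gave a limit, the step cannot be sized exactly, but removing the 2,4-dichlorophenyl and adding a single group on that ring, as in compound 2, is expected to return the number into the measurable range, a step of an at least 3.3-fold lower number from compound 3 to compound 4 (0.52 log units; beyond the scatter). Compound 4 is therefore estimated at 30000 nM, between 8000 nM and 120000 nM, with a real chance of another limit.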

Compound 4, half-maximal inhibitory concentration: > 100000 nM
Compound 4 gave a limit, no number; the forecaster's own chance of this, stated with the estimate: 30%; middle value at least 3.3-fold (0.52 log units) from the limit.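

The nitro group reverses the effect of the methyl group on the same ring, with an at least 8.5-fold higher number from compound 2 to compound 4 (0.93 log units; beyond the scatter) in this assay, so a single added group on this phenyl does not by itself give a measurable number. Set against the plain phenyl, the nitro group also moves the number the other way, with an at least 2.3-fold higher number from compound 1 to compound 4 (0.36 log units; beyond the scatter), whereas the methyl group had lowered it, with a 3.7-fold lower number from compound 1 to compound 2 (0.56 log units; beyond the scatter); the direction of the change at this position therefore depends on which group is added, and not merely on a group being present. Compound 3 and compound 4 both gave only a limit, so the step between them cannot be read, and the two analogues share the weak end of the series: the limit of > 100000 nM in this assay, at which 2 of the 4 values shown sit.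

The compounds shown leave open whether the lower number of compound 2 is particular to methyl or would persist with an ethyl group, a methoxy group or an amine in its place on the ring. They also leave open how far compound 3 and compound 4 lie beyond the limit, and whether they differ from each other at all.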